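A few compounds are considered here, and "the series" means these few. Any claim that something is new, unique, unknown or untested is made for them only; others in the source may bear on it.

Measured so far in an ADME assay on Huh-7 cells (Homo sapiens) for cytotoxicity, with a stated time of 72 h; on this read-out higher numbers stand for lower toxicity in this test and lower numbers for higher toxicity in this test:

Compound 1, `CC(C)CCN1C(=O)C(C2=NS(=O)(=O)c3cc(NS(C)(=O)=O)ccc3N2)=C(O)C2CCCC21`: > 1000 nM
Compound 2, `CS(=O)(=O)Nc1ccc2c(c1)S(=O)(=O)N=C(C1=C(O)C3CCCC3N(C3CCCC3)C1=O)N2`: "not determined" (no result reported)

In this assay compound 1 gives > 1000 nM, which is a limit of the assay and not a number; it sits at the limit of > 1000 nM in this assay, at which 1 of the 2 values shown sits. Compound 2 stands on no number here: its result in this assay is "not determined" (no result reported). The piece follows the step from compound 2 to compound 3, whose structure is `CS(=O)(=O)Nc1ccc2c(c1)S(=O)(=O)N=C(C1=C(O)C3CCCC3N(CC3CCC3)C1=O)N2`. The change is cyclobutylmethyl in place of cyclopentyl on an amide-type nitrogen in a ring. Among the measured compounds shown here, no measured step between compounds is available to anchor the size of this change, and the one measured value is only a limit, so no shift beyond the usual scatter of this assay is expected in either direction for compound 3. Compound 3 is expected to give about 1500 nM in this assay, with a range from 500 nM to 6000 nM, and the assay may well report only a limit again.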

Compound 3, half-maximal cytotoxic concentration: > 33000 nM
Compound 3 gave a limit, no number; the forecaster's own chance of this, stated with the estimate: 75%; middle value at least 22-fold (1.34 log units) away from the limit.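

In this assay compound 3 gives > 33000 nM, which is a limit and not a number. No step can be read from it: compound 1 also stands at a limit, and compound 2 has no result. Still open, on these data alone, is whether cyclobutylmethyl in place of cyclopentyl changes this read-out at all.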